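This account rests on a few compounds, and the source may have more. Where it says the series, first, only, none or still open, it means among the compounds named here.

Measured in a functional assay on A-375 cells (Homo sapiens) for antiproliferative activity, read by MTT assay, with a stated time of 24 h, tested at 0.41 ug/mL; on this read-out higher numbers stand for a stronger effect at the one concentration tested and lower numbers for a weaker effect:
compound 1, `CCc1ccc2nc(C(=O)Nc3c(F)cc(-c4cccc(F)c4)cc3F)c(C)c(C(=O)O)c2c1`, gives 6.13%
compound 2, `CCOc1ccc2nc(C(=O)Nc3c(F)cc(-c4cccc(F)c4)cc3F)c(C)c(C(=O)O)c2c1`, gives 11.2%

Among the compounds with values here, of these two numbers the one for compound 2 is the larger, but its only neighbour, compound 1, sits within the scatter of it, so the two are not separated. Within the data shown here, the single measured step, a number 5.1 percentage points higher from compound 1 to compound 2 (within the scatter), is itself within the scatter. Compound 3, `COc1ccc2nc(C(=O)Nc3c(F)cc(-c4cccc(F)c4)cc3F)c(C)c(C(=O)O)c2c1`, is not yet measured; it differs from compound 2 by hydrogen in place of methyl on a saturated chain carbon bound to an oxygen on an aromatic ring. Among the measured compounds shown here, no measured step touches the chain on the oxygen on the aromatic ring, so the one step is only an indirect guide: the exchange at that aromatic carbon in a number 5.1 percentage points higher from compound 1 to compound 2 (within the scatter) moved the number little. A further shortening of the same chain is therefore expected to give no step beyond the scatter in this assay, with no clear direction. The estimated step is a number 2.2 percentage points lower from compound 2 to compound 3 (within the scatter). Compound 3 is expected to give about 9%, within 1% to 18%.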

Compound 3, a percentage reported as inhibition, at one concentration (the size of the read-out at that concentration, not a potency): 3.87%
Beside the measured number, compound 3's estimate is 5.1 percentage points above it; measured number inside the range.
By their numbers in this assay, from the lowest: compounds 3, 1 and 2 (each within the scatter of the next).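

Notes on the chain on the oxygen on the aromatic ring: in this assay, the exchange of ethoxy for methoxy gives a number 7.3 percentage points lower from compound 2 to compound 3 (within the scatter), and this is the first step that reads this chain directly. Methoxy in place of ethyl gives a number 2.3 percentage points lower from compound 1 to compound 3 (within the scatter), so no exchange among ethyl, ethoxy and methoxy on this aromatic carbon has yet given a step beyond the scatter. The three compounds therefore stay unseparated, and no order can be drawn among them.

On these data alone, whether a group of another kind on this aromatic carbon, such as an amine or a butoxy chain, would give a step beyond the scatter remains open. A read-out at one concentration also gives no potency for any of the three compounds.

Nothing available on these compounds speaks to the cause of these small steps.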